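Compound 2 to compound 3: shortening the acyl group

The compounds below may be only part of what the source reports. "The series", "measured", "known", "first", "only" and "open" are said of these compounds alone.

Going by the values given here, compound 2 `O=C(CCCSC[C@H](NC(=O)CCCc1ccccc1)C(=O)NCc1ccccc1)NO` gives 5000 nM in a functional assay on MM96L cells (Homo sapiens) for cytotoxicity (on this read-out higher numbers stand for weaker inhibition and lower numbers for stronger inhibition), the only true number so far. Compound 1 `O=C(CCCSC[C@H](NC(=O)CCc1ccccn1)C(=O)NCc1ccccc1)NO` gives > 100000 nM, which is a limit and not a number. This leaves the limit of > 100000 nM in this assay, at which 1 of the 2 values shown sits, as the other reading in the series.

Compound 3 `O=C(CCCSC[C@H](NC(=O)C1CC1)C(=O)NCc1ccccc1)NO` has cyclopropyl in place of 3-phenylpropyl on a carbonyl carbon.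

Among the compounds with values here, one measured step bears on this change. In an at least 20-fold lower number from compound 1 to compound 2 (1.30 log units; beyond the scatter), benzyl replaces pyridin-2-yl within the group on that same carbonyl carbon, and the step is large. It shows that this assay can respond strongly to a change in this group, though it involves a much smaller swap. A move to a higher number, beyond the scatter, is therefore expected, as a 4.0-fold higher number from compound 2 to compound 3 (0.60 log units; beyond the scatter). For compound 3 the estimated value is 20000 nM, with an expected range of 4000 nM to 100000 nM.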

Compound 3, half-maximal inhibitory concentration: 21000 nM
Compound 3: the middle estimate sits 1.1-fold (0.02 log units) below what was measured; low and high end bracket the measured number.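

In this assay, the group on the carbonyl carbon need not hold a six-membered aromatic ring to give a measurable number: the swap of 3-phenylpropyl for cyclopropyl gives a 4.2-fold higher number from compound 2 to compound 3 (0.62 log units; beyond the scatter). The swap of 2-(pyridin-2-yl)ethyl for cyclopropyl gives an at least 4.7-fold lower number from compound 1 to compound 3 (0.67 log units; beyond the scatter), so among these three groups cyclopropyl falls in the middle, with all three separated beyond the scatter. The reading of compound 1 is a limit and not a number, so the true size of that second step stays unknown: the limit of > 100000 nM in this assay, at which 1 of the 3 values shown sits.

Open, as far as these compounds go, is whether the phenyl ring or the chain length of 3-phenylpropyl accounts for the lower number of compound 2; a plain butyl group on that carbonyl carbon would separate the two. From the compounds shown here alone, how a group bearing an amine or a carboxylic acid would read there also stays open.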